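Two Halogens Kept, the Aryl Group Exchanged

This account rests on a few compounds, and the source may have more. Where it says the series, first, only, none or still open, it means among the compounds named here.

Compound 1, `CC(C)(C)c1cc(/C=C/S(=O)(=O)Cc2ccc(Nc3ncnc4ccccc34)cc2)cc(C(C)(C)C)c1O`: in a functional assay on NCI/ADR-RES cells (Homo sapiens) for inhibition (a lower number here means a stronger inhibitor of growth, a higher number a weaker inhibitor of growth), compound 1 sits at the limit > 100000 nM.
Compound 2, `O=S(=O)(/C=C/c1ccc(Cl)cc1)Cc1ccc(Nc2ncnc3ccccc23)cc1`: in this assay compound 2 also sits at the limit > 100000 nM.
Compound 3, `O=S(=O)(/C=C/c1ccc(Cl)cc1Cl)Cc1ccc(Nc2ncnc3ccccc23)cc1`: in this assay compound 3 gives 5000 nM.

Compound 3 is therefore the only one of the three with a real number; the other two values are limits, as summed up by the limit of > 100000 nM in this assay, at which 2 of the 3 values shown sit. Within the data shown here, the one step between neighbours, an at least 20-fold lower number from compound 2 to compound 3 (1.30 log units; beyond the scatter), shows that the second chloro on the aryl group made the difference between a compound without a measurable number and one with.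

Compound 4, `O=S(=O)(/C=C/c1ccc(C(F)(F)F)cc1F)Cc1ccc(Nc2ncnc3ccccc23)cc1`, keeps the shared core and changes only the aryl group: 2-fluoro-4-(trifluoromethyl)phenyl in place of 2,4-dichlorophenyl on a double-bonded chain carbon bound to a double-bonded chain carbon. The change keeps a substituent at each of the two places where compound 3 carries a chlorine, but swaps what sits there. Among the measured compounds shown here, no measured step involves such a swap, so the step of an at least 20-fold lower number from compound 2 to compound 3 (1.30 log units; beyond the scatter) speaks only to having a second substituent at all, not to its nature. The step of no change at the digits printed from compound 3 to compound 4 (within the scatter) is expected to be small, within the scatter. For compound 4 the estimate in this assay is 5000 nM, with a range from 1500 nM to 20000 nM.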

Compound 4, concentration for 50% growth inhibition: 100000 nM
For compound 4 the middle estimate is 20-fold (1.30 log units) below the measured one; the whole stated range lies below it.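

Exchanging 2,4-dichlorophenyl for 2-fluoro-4-(trifluoromethyl)phenyl gives a 20-fold higher number from compound 3 to compound 4 (1.30 log units; beyond the scatter) in this assay. A substituent at each of the two places is therefore not enough to keep the growth inhibition of compound 3, and what sits there also counts. The aromatic ring of carbon stays, and neither group carries a hydrogen-bond donor or acceptor, so the large step comes with no change in those counts, only with different atoms on the ring and more heavy atoms in the entering group. Compound 2 sits at a limit, > 100000 nM. The step of a number no higher from compound 2 to compound 4 (the limit leaves the size open) therefore cannot be read, and limits restrict what this small set can say: the limit of > 100000 nM in this assay, at which 2 of the 4 values shown sit.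

The fluorine and the trifluoromethyl group both enter in the same step, so the compounds shown cannot tell which of the two exchanges carries the change. On these data alone, it also stays open how the number in this assay would move with a methoxy group, an amine or a carboxylic acid at either of these two places on the aryl group.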